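A few compounds are considered here, and "the series" means these few. Any claim that something is new, unique, unknown or untested is made for them only; others in the source may bear on it.

Measured so far in an in vitro ADME assay on microsomes from liver (Homo sapiens) for metabolic stability; a lower number here means that the compound disappears faster, a higher number that the compound lasts longer:
- compound 1 `c1ccc2c(c1)CC(c1nc3ccc(-c4cn[nH]c4)cc3[nH]1)CO2`: 0.333 h
- compound 2 `Nc1nccc(-c2ccc3nc(C4COc5ccccc5C4)oc3c2)n1`: 0.95 h
- compound 3 `Cc1[nH]ncc1-c1ccc2nc(C3COc4ccccc4C3)oc2c1`: 1.17 h

Compound 1 gives the lowest of the three numbers in this assay; compound 2 and compound 3 both sit above it, each beyond the scatter. Compound 4 `c1ccc2c(c1)CC(c1nc3ccc(-c4ccncc4)cc3[nH]1)CO2` is not yet measured. It differs from compound 1 in one place: pyridin-4-yl in place of 1H-pyrazol-4-yl on an aromatic carbon.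

For the measured compounds named here, the only measured step, a 1.2-fold higher number from compound 2 to compound 3 (0.09 log units; within the scatter), is also a swap of one aromatic ring for another at the same kind of position, but on a different core, and it stays within the scatter. Going by the values given here, no step on the core of compound 1 is available. The closest evidence therefore points to a small change in this assay for a ring swap of this sort, with no direction established beyond the scatter.

For compound 4 the expectation in this assay is 0.45 h, in the range 0.2 h to 1 h. That expected step, a 1.4-fold higher number from compound 1 to compound 4 (0.13 log units; within the scatter), would stay within the scatter of the value of compound 1.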

Compound 4, half-life: 0.483 h
The estimate for compound 4 lay 1.1-fold (0.03 log units) below the measured number; low and high end bracket the measured number.
By their numbers in this assay, from the lowest: compounds 1, 4, 2 and 3 (each within the scatter of the next, the first and the last beyond it).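

On the core of compound 1, this assay now has a step at this position: a 1.5-fold higher number from compound 1 to compound 4 (0.16 log units; within the scatter), which stays within the scatter. The swap takes out a five-membered ring carrying a hydrogen-bond donor and puts in a six-membered ring with no donor, so on this core the donor of 1H-pyrazol-4-yl is not required to keep the number within the scatter of compound 1. Nothing available explains this result or ties it to any property of either ring.

The compounds shown leave open whether a non-aromatic group on this aromatic carbon, such as piperidin-4-yl or a carboxylic acid, would move the number beyond the scatter. They also leave open whether pyridin-4-yl would give a similar step on the core of compound 2.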